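The source may report more compounds than this note shows. Statements on the series, on what has been measured and on what is new or still open speak of the compounds shown alone.

In a functional assay on HL-60 cells (Homo sapiens) for cytotoxicity, read by WST assay, with a stated time of 48 h (a lower number here means a stronger inhibitor, a higher number a weaker inhibitor), compound 1 `COc1ccc(/C=C/C[C@H]2C[C@@H]([C@@H](O)c3ccccc3)CO[C@@H]2c2ccccc2)cc1` gives 9010 nM. Within the data shown here, only one other compound yields a number here: compound 3 `COc1cccc(/C=C/C[C@H]2C[C@@H]([C@@H](O)c3ccccc3)CO[C@@H]2c2ccccc2)c1`, which gives 9620 nM, and the step of a 1.1-fold higher number from compound 1 to compound 3 (0.03 log units; within the scatter) shows the two sitting together. Compound 2 `O[C@@H](c1ccccc1)[C@H]1CO[C@H](c2ccccc2)[C@@H](C/C=C/c2ccncc2)C1` reaches only a limit of the assay, > 100000 nM. That limit, (the limit of > 100000 nM in this assay, at which 1 of the 3 values shown sits), is what makes the step of an at least 11-fold higher number from compound 1 to compound 2 (1.04 log units; beyond the scatter) a large one.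

Compound 4 `O=[N+]([O-])c1ccc(/C=C/C[C@H]2C[C@@H]([C@@H](O)c3ccccc3)CO[C@@H]2c2ccccc2)cc1` differs from compound 1 at a single place: nitro in place of methoxy on an aromatic carbon. Neither measured step repeats this change. The step from compound 1 to compound 3, which puts 3-methoxyphenyl in place of 4-methoxyphenyl, leaves the number within the scatter; the step from compound 1 to compound 2, which puts pyridin-4-yl in place of 4-methoxyphenyl, loses the number altogether. A change that keeps the six-membered aromatic ring of carbon only and exchanges just the group para to the large group sits nearer the first case than the second, so the expected step of a 1.3-fold higher number from compound 1 to compound 4 (0.12 log units; within the scatter) is small, with the uncertainty leaning toward a weaker inhibitor. Compound 4 is accordingly estimated at 12000 nM, between 4000 nM and 40000 nM.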

Compound 4, half-maximal inhibitory concentration: 4880 nM
The estimate for compound 4 lay 2.5-fold (0.39 log units) above the measured number; measured number inside the range.
By their numbers in this assay, from the lowest: compounds 4, 1 and 3 (each within the scatter of the next). At a limit, above all of these: compound 2.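

In this assay, among these compounds, the exchange of methoxy for nitro on an aromatic carbon, para to a large group, gives a 1.8-fold lower number from compound 1 to compound 4 (0.27 log units; within the scatter) and shows that this place accepts a different group, whereas the earlier compounds only showed a methoxy group shifted on the ring. The comparison with the other methoxy compound gives a 2.0-fold lower number from compound 3 to compound 4 (0.29 log units; within the scatter) and adds that all three compounds with a six-membered aromatic ring of carbon only on this chain stay together, with no order among neighbours in the series. Among the compounds shown here, the one large change remains the one to pyridin-4-yl, seen again in an at least 20-fold lower number from compound 2 to compound 4 (1.31 log units; beyond the scatter), and that step is a bound and not a measured gap, since compound 2 stands at a limit of the assay: the limit of > 100000 nM in this assay, at which 1 of the 4 values shown sits.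

What the compounds shown leave open is whether an amine, a carboxylic acid or a fluorine atom at the same place would also leave the number where it is. They also leave open whether nitro on the 3-substituted ring, or a longer chain in place of the present one, would give the same picture.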